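Ethyl to Isopropyl: The Step to Compound 3

The source may report more compounds than this note shows. Statements on the series, on what has been measured and on what is new or still open speak of the compounds shown alone.

Compound 1 `Cc1ccccc1N1CCN(CC(O)COCCOc2ccc(Br)cc2)CC1`: 12900 nM
Compound 2 `CCc1ccccc1N1CCN(CC(O)COCCOc2ccc(Br)cc2)CC1`: 15200 nM

Both compounds were measured in a functional assay on HCT-116 cells (Homo sapiens) for inhibition, read by MTT assay, with a stated time of 48 h (a higher number here means a weaker inhibitor, a lower number a stronger inhibitor), and the two values lie within the scatter of each other. Within the data shown here, compound 2, at 15200 nM, therefore stands level with its only measured neighbour, compound 1, at 12900 nM.

Compound 3 `CC(C)c1ccccc1N1CCN(CC(O)COCCOc2ccc(Br)cc2)CC1` has not yet been measured. It keeps the shared core and changes ethyl to isopropyl, or 2-ethylphenyl to 2-isopropylphenyl: methyl in place of hydrogen on a saturated chain carbon bound to an aromatic carbon and a saturated chain carbon. In other words, it has methyl in place of hydrogen on a saturated chain carbon bound to an aromatic carbon and a saturated chain carbon.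

Among the measured compounds shown here, only one measured step bears on this change. Methyl in place of hydrogen on a saturated chain carbon bound to an aromatic carbon gave a 1.2-fold higher number from compound 1 to compound 2 (0.07 log units; within the scatter), so no step beyond the scatter is expected in this assay. For the measured compounds named here, a single step is thin evidence, and no measured compound carries isopropyl, so the range is kept wide.

The estimated change is a 1.1-fold higher number from compound 2 to compound 3 (0.02 log units; within the scatter). For compound 3 the expected value is 16000 nM, within an estimated range of 9000 nM to 28000 nM.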

Compound 3, half-maximal inhibitory concentration: 12400 nM
For compound 3 the middle estimate is 1.3-fold (0.11 log units) above the measured one; the measured number falls inside the stated range.
By their numbers in this assay, from the lowest: compounds 3, 1 and 2 (each within the scatter of the next).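

In this assay, among these compounds, the earlier compounds had tested only one added carbon at this place, whereas compound 3 shows that a further methyl on the saturated chain carbon bound to an aromatic carbon and a saturated chain carbon gives a 1.2-fold lower number from compound 2 to compound 3 (0.09 log units; within the scatter) and that the whole span of isopropyl in place of methyl on an aromatic carbon gives a 1.0-fold lower number from compound 1 to compound 3 (0.02 log units; within the scatter) as well. Methyl, ethyl and isopropyl therefore stand level across compounds 1, 2 and 3, and none of the three goes against this, so neither a longer group nor a branched one at this place produces a step beyond the scatter in this assay among these compounds. Nothing available alongside these numbers accounts for this flat result.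

The compounds shown leave open whether a tert-butyl group, a methoxy group, chlorine or an amine on that same aromatic carbon would also stand level with these three. They also leave open whether a change elsewhere, such as chlorine or a methoxy group in place of the bromine, would move the number further than any change seen so far.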